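The source may report more compounds than this note shows. Statements on the series, on what has been measured and on what is new or still open speak of the compounds shown alone.

Among the compounds with values here, compound 2 `O=C(Nc1cccc(CNc2nccnc2Cl)c1)Nc1cccc(C(F)(F)F)c1` was tested in a functional assay on MGC-803 cells (Homo sapiens) for antiproliferative activity, read by MTT assay, with a stated time of 48 h (a higher number here means a weaker inhibitor, a lower number a stronger inhibitor), where compound 2 gave 7290 nM, the higher of the two numbers known, though compound 1 `CCOc1ccc(NC(=O)Nc2cccc(CNc3nccnc3Cl)c2)cc1` in this assay gave 7240 nM, a gap within the scatter. Compound 3 `O=C(Nc1cccc(Cl)c1)Nc1cccc(CNc2nccnc2Cl)c1` differs from compound 2 in one place: chloro in place of trifluoromethyl on an aromatic carbon. Within the data shown here, since the two compounds measured so far sit together, and nothing in them points to a shift for this change, the step from compound 2 to compound 3 is expected to be a 1.0-fold lower number from compound 2 to compound 3 (0.02 log units; within the scatter), no larger than the scatter in either direction. Compound 3 is therefore estimated at 7000 nM, with a range from 3000 nM to 17000 nM.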

Compound 3, half-maximal inhibitory concentration: 5330 nM
Compound 3: middle estimate off by 1.3-fold (0.12 log units), on the high side; low and high end bracket the measured number.
By their numbers in this assay, from the lowest: compounds 3, 1 and 2 (each within the scatter of the next).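

In this assay chloro in place of trifluoromethyl on this aromatic carbon gives a 1.4-fold lower number from compound 2 to compound 3 (0.14 log units; within the scatter) and so shows that a group of one heavy atom and a group of four read alike here. The change of 3-chlorophenyl in place of 4-ethoxyphenyl gives a 1.4-fold lower number from compound 1 to compound 3 (0.13 log units; within the scatter) and likewise moves nothing beyond the scatter. No evidence is available to explain why these numbers sit together. From the compounds shown here alone, whether an amine, a carboxylic acid or a longer chain on this ring would shift the number beyond the scatter remains open.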